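The source may hold more compounds than are shown below. What is called first, only, known or untested is meant among the compounds shown, and "the series" means these compounds.

Compound 1 `Cc1ccc2c(c1)[n+]([O-])c(N)n[n+]2[O-]` gives in a physicochemical assay for solubility, in the presence of a further agent that is not named here (a higher number here means a more soluble compound, a lower number a less soluble compound), 3000000 nM. Compound 2 `CCN(CC)CCNc1n[n+]([O-])c2ccc(Cl)cc2[n+]1[O-]` gives in this assay 23000000 nM. Compound 3 `Cc1ccc2c(c1)[n+]([O-])c(NCCN(C)C)n[n+]2[O-]` reports > 51000000 nM, which is a limit of the assay rather than a number.

Compound 3 therefore stands at the top of the series, at the limit of this assay where one of the three values sits (the limit of > 51000000 nM in this assay, at which 1 of the 3 values shown sits). Among the measured compounds shown here, its only measured neighbour is compound 1, and that step, an at least 17-fold higher number from compound 1 to compound 3 (1.23 log units; beyond the scatter), concerns attaching the 2-(dimethylamino)ethyl chain to the ring nitrogen, not altering a chain already there.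

Compound 4 `CCN(CC)CCNc1n[n+]([O-])c2ccc(C)cc2[n+]1[O-]` is the next compound. It differs from compound 3 by diethylamino in place of dimethylamino on a saturated chain carbon, two bonds along the chain from a nitrogen on an aromatic ring. For the measured compounds named here, no measured step covers this swap directly. Compound 2 carries the same 2-(diethylamino)ethyl chain on a core with chloro in place of methyl and gives a number rather than a limit, but the ring substituent differs as well, so it bears only loosely on compound 4.

Going by the values given here, with no step on record for the dimethylamino-to-diethylamino change, the expected step of an at least 1.1-fold lower number from compound 3 to compound 4 (0.05 log units; that floor lies within the scatter) is none beyond the scatter. Compound 4 is thus expected to give about 45000000 nM, between 18000000 nM and 110000000 nM, with a fair chance of again reaching only the limit.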

Compound 4, solubility: > 49000000 nM
Compound 4: only a limit was reported (the forecaster's own chance of this, stated with the estimate: 40%); middle value at least 1.0-fold (0.03 log units) away from the limit.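

In this assay compound 4 also ends at a limit of the assay rather than a number: the limit of > 49000000 nM in this assay, at which 1 of the 4 values shown sits. Compound 3 is a limit as well, so the step for diethylamino in place of dimethylamino on the chain cannot be read, and the only finding at this position is that the compound with the larger amine still reaches a limit. The readable steps concern other places: attaching the 2-(diethylamino)ethyl chain to the core of compound 1 gives an at least 16-fold higher number from compound 1 to compound 4 (1.21 log units; beyond the scatter), in the same direction as the 2-(dimethylamino)ethyl chain in an at least 17-fold higher number from compound 1 to compound 3 (1.23 log units; beyond the scatter), while methyl in place of chloro on an aromatic carbon gives an at least 2.1-fold higher number from compound 2 to compound 4 (0.32 log units; beyond the scatter), so that with the same chain the ring substituent matters beyond the scatter.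

Going by these compounds, whether dimethylamino and diethylamino differ at all in this measurement stays open as long as both compounds sit at limits, and a pair on the chloro core with a number on each side would be needed to read that change. Also open, on these data alone, is how a longer chain, such as 3-(diethylamino)propyl, or a morpholine at the chain end would read on the same core.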